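A few compounds are considered here, and "the series" means these few. Any claim that something is new, unique, unknown or untested is made for them only; others in the source may bear on it.

In a functional assay on MCF7 cells (Homo sapiens) for antiproliferative activity, read by MTT assay, with a stated time of 72 h (on this read-out lower numbers stand for stronger inhibition and higher numbers for weaker inhibition), compound 1 (`CCn1c(C(=O)NCc2ccc(OC)cc2)ccc1C(CC)(CC)c1ccc(C#CC(O)(CC)CC)c(C)c1`) gives > 50000 nM, which is a limit of the assay and not a number. In this assay, compound 2 (`CCn1cc(C(CC)(CC)c2ccc(C#CC(O)(CC)CC)c(C)c2)cc1C(=O)NCC(=O)OC`) gives 26500 nM and compound 3 (`CCn1cc(C(CC)(CC)c2ccc(C#CC(O)(CC)CC)c(C)c2)cc1C(=O)OCCO`) gives 1880 nM, the lower of the two actual numbers in the series.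

The next change leads from compound 3 to compound 4 (`CCn1cc(C(CC)(CC)c2ccc(C#CC(O)(CC)CC)c(C)c2)cc1C(=O)N[C@H](C(=O)O)C(C)C`): (1-carboxy-2-methylpropyl)amino in place of 2-hydroxyethoxy on a carbonyl carbon. Here (1-carboxy-2-methylpropyl)amino takes the place of 2-hydroxyethoxy on a carbonyl carbon. Among the measured compounds shown here, only one measured step bears on this carbonyl carbon: a 14-fold lower number from compound 2 to compound 3 (1.15 log units; beyond the scatter), a large step in which 2-hydroxyethoxy took the place of ((methoxycarbonyl)methyl)amino. For the measured compounds named here, compound 4 restores a substituted amino group there, so much of that step is expected to reverse, although no measured compound carries the free carboxy group. From the size of a 14-fold lower number from compound 2 to compound 3 (1.15 log units; beyond the scatter), a higher number is expected, an estimated 5.3-fold higher number from compound 3 to compound 4 (0.73 log units; beyond the scatter). Compound 4 is estimated at 10000 nM, with an expected range of 2000 nM to 45000 nM.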

Compound 4, half-maximal inhibitory concentration: 12600 nM
Estimate against measurement, compound 4: 1.3-fold (0.10 log units) below; low and high end bracket the measured number.
By their numbers in this assay, from the lowest: compound 3; then compound 4; then compound 2. At a limit, above all of these: compound 1.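

In this assay, the change to (1-carboxy-2-methylpropyl)amino on the carbonyl carbon gives a 6.7-fold higher number from compound 3 to compound 4 (0.83 log units; beyond the scatter), so the low number of compound 3 is not kept when a substituted amino group returns. Comparing the two amino-linked compounds, 1-carboxy-2-methylpropyl in place of (methoxycarbonyl)methyl on the amide-type nitrogen gives a 2.1-fold lower number from compound 2 to compound 4 (0.32 log units; beyond the scatter), a smaller step than the exchange of 2-hydroxyethoxy for either amino group. Nothing measured here accounts for either step.

Still open, on these data alone, is whether the low number of compound 3 goes with the ester link or with its hydroxyl, which a 2-hydroxyethyl amide at this carbonyl carbon would separate. The contributions of the carboxylic acid and the isopropyl side chain in compound 4 also remain unseparated, and the glycine amide with a free carboxylic acid would address this.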